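The compounds below may be only part of what the source reports. "The series", "measured", "known", "first", "only" and "open" are said of these compounds alone.

Measured so far:
compound 1 `COc1cc(OC)c2c(=O)cc(C(=O)Nc3ccc(C4CCCCC4)cc3)[nH]c2c1` gives > 43100 nM in a functional assay on HepG2 cells (Homo sapiens) for antiproliferative activity, with a stated time of 72 h; a higher number here means that more compound is needed for the effect, a lower number that less compound is needed
compound 2 `COc1cc(OC)c2c(=O)cc(C(=O)Nc3ccc(N4CCN(C)CC4)cc3)[nH]c2c1` gives > 19800 nM in this assay

Both entries are limits of the assay, not numbers. The result for compound 1 is a limit; it sits at the limit of > 43100 nM in this assay, at which 1 of the 2 values shown sits. The result for compound 2 is likewise a limit; it sits at the limit of > 19800 nM in this assay, at which 1 of the 2 values shown sits. For the measured compounds named here, the only measured step is a step that the two limits leave unreadable from compound 1 to compound 2; with a limit at either end its size cannot be read, so there is no usable guide to how the group on this aromatic carbon moves the read-out. Compound 2 therefore stands only at a limit, with no number behind it and no readable step reaching it.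

Compound 3 `COc1cc(OC)c2c(=O)cc(C(=O)Nc3ccc(Oc4ccc([N+](=O)[O-])cc4)cc3)[nH]c2c1` differs from compound 2 by 4-nitrophenoxy in place of 4-methylpiperazin-1-yl on an aromatic carbon. Going by the values given here, no measured step bears directly on this change; the one step that exists, from cyclohexyl to 4-methylpiperazin-1-yl, is itself unreadable. The expectation for compound 3 is thus another limit rather than a number. The estimate for compound 3 is 30000 nM, with a range from 5000 nM to 120000 nM. The implied step that the limit leaves unreadable from compound 2 to compound 3 is expected to be no change beyond the scatter.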

Compound 3, half-maximal effective concentration: > 22900 nM
Compound 3 gave a limit, no number; the forecaster's own chance of this, stated with the estimate: 70%; the middle value does not contradict the limit.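

In this assay compound 3 stands at a limit, not a number: the limit of > 22900 nM in this assay, at which 1 of the 3 values shown sits.

The steps among compound 1, compound 2 and compound 3 all run between limits, so none of them can be read. The compounds shown leave open at what concentration any of the three reaches the half-maximal effect, and how the group on this aromatic carbon moves it.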